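This account rests on a few compounds, and the source may have more. Where it says the series, first, only, none or still open, it means among the compounds named here.

Compound 1, `COc1ccc(C(=O)c2ccc3c(c2)C=CC(C)(C)O3)c(NC(=O)CO)c1`, in a functional assay on A2780 cells (Homo sapiens) for antiproliferative activity, read by MTT assay, with a stated time of 48 h (a higher number here means a weaker inhibitor, a lower number a stronger inhibitor), gives 130 nM.
Compound 2, `COc1ccc(C(=O)c2ccc3c(c2)C=CC(C)(C)O3)c(NC(=O)CN(C)C)c1`, in this assay gives 1020 nM.
Compound 3, `C=C(c1cc(OC)c(OC)c(OC)c1)c1ccc(OC)c(O)c1NC(=O)CN(C)C`, in this assay gives 90 nM.

Compounds 1 and 2 share one core and differ in a single place: hydroxy in place of dimethylamino on a saturated chain carbon bound to a carbonyl carbon. That change gave the step of a 7.8-fold lower number from compound 2 to compound 1 (0.89 log units; beyond the scatter). Compound 3 is built on a different core; how its core differs from that of compound 2 is not broken down here. The values of compound 3 and compound 1 lie within the usual scatter of each other, so they read as alike, while compound 2 stands apart from both beyond the scatter.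

Compound 4, `C=C(c1cc(OC)c(OC)c(OC)c1)c1ccc(OC)c(O)c1NC(=O)CO`, has not yet been tested. It differs from compound 3 in one place: hydroxy in place of dimethylamino on a saturated chain carbon bound to a carbonyl carbon. Within the data shown here, this is the same change as the one from compound 2 to compound 1, made at the same place, but now on the core of compound 3, which has no measured precedent of its own.

If the change repeats its effect, a step of about the size seen in a 7.8-fold lower number from compound 2 to compound 1 (0.89 log units; beyond the scatter) is expected. The step expected here, a 4.5-fold lower number from compound 3 to compound 4 (0.65 log units; beyond the scatter), rests on one earlier pair only, and is kept a little more cautious for that reason. Compound 4 is therefore expected to give 20 nM, in the range from 7 nM to 60 nM.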

Compound 4, half-maximal inhibitory concentration: 20 nM
For compound 4 middle estimate and measured number coincide at the digits printed; the measured number falls inside the stated range.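

Replacing dimethylamino with hydroxy on a saturated chain carbon bound to a carbonyl carbon gave, in this assay, a 4.5-fold lower number from compound 3 to compound 4 (0.65 log units; beyond the scatter), so on this second core the change moved the number in the same direction as on the first. Set side by side, the two steps point the same way and cannot be told apart in size: the same change on two cores in this assay, a 7.8-fold lower number (0.89 log units; beyond the scatter) from compound 2 to compound 1 and a 4.5-fold lower number (0.65 log units; beyond the scatter) from compound 3 to compound 4, 1.7-fold (0.24 log units) apart, within the scatter of two such steps. Among these compounds, this is still only two matched pairs on two cores in a single cell assay, so it shows that the change carried over in this case, but it does not show that it would carry to any further core, and it does not explain why the hydroxy compounds give the lower numbers.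

The compounds shown carry only dimethylamino or hydroxy at this place, so it remains open whether a methoxy group, a primary amine or a carboxylic acid there would track the hydroxy compounds, the dimethylamino compounds or neither. From the compounds shown here alone, a longer chain carrying the hydroxy is equally open, as is whether the same gap between the two groups would appear on other cell lines.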